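A few compounds are considered here, and "the series" means these few. Any claim that something is new, unique, unknown or untested is made for them only; others in the source may bear on it.

Working notes on the series, read in a functional assay on the whole organism for inhibition, with Mus musculus as the target; on this read-out higher numbers stand for an effect only at larger amounts of compound and lower numbers for an effect already at smaller amounts. Compound 1 `CCCCNC(=O)Nc1cccc2c1CN(C)CC2c1ccccc1` gives 23 mg/kg and compound 2 `CN1Cc2c(NC(=O)OCc3ccccc3)cccc2C(c2ccccc2)C1` gives 16 mg/kg, and a 1.4-fold lower number from compound 1 to compound 2 (0.16 log units; within the scatter) stays within the scatter. Compound 3 `CCNCCC(=O)Nc1cccc2c1CN(C)CC2c1ccccc1` gives > 160 mg/kg, which is a limit of the assay and not a number. The two steps that reach it, an at least 6.9-fold higher number from compound 1 to compound 3 (0.84 log units; beyond the scatter) and an at least 10-fold higher number from compound 2 to compound 3 (1.00 log units; beyond the scatter), are both beyond the scatter.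

Compound 4 `CC(C)NCCC(=O)Nc1cccc2c1CN(C)CC2c1ccccc1` differs from compound 3 by methyl in place of hydrogen on a saturated chain carbon bound to an amine nitrogen and a saturated chain carbon, so that ethylamino becomes isopropylamino. Among the measured compounds shown here, no measured step covers this change directly. The steps to compound 3 replace the whole group on the carbonyl carbon, whereas here the 2-(ethylamino)ethyl group stays and only gains the methyl. No step beyond the scatter is therefore expected in this assay, and another result reported only as a limit is likely. The expectation rests on the limit of compound 3, > 160 mg/kg. The expected step is a step that the limit leaves unreadable from compound 3 to compound 4. For compound 4 the estimated value is 200 mg/kg, with an expected range of 80 mg/kg to 400 mg/kg.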

Compound 4, dose for half-maximal effect: about 125 mg/kg
Estimate against measurement, compound 4: 1.6-fold (0.20 log units) above; low and high end bracket the measured number.
By their numbers in this assay, from the lowest: compounds 2 and 1 (each within the scatter of the next); then compound 4. At a limit, above all of these: compound 3.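

In this assay compound 3 gives > 160 mg/kg as a limit of the assay and not a number. Methyl in place of hydrogen on the saturated chain carbon bound to the amine nitrogen yields a readable number for the 2-(isopropylamino)ethyl group, though an at least 1.2-fold lower number from compound 3 to compound 4 (0.10 log units; that floor lies within the scatter) gives only a floor for this change. That number also puts a size on the gap to the other two groups on the carbonyl carbon, with a 7.8-fold higher number from compound 2 to compound 4 (0.89 log units; beyond the scatter) and a 5.4-fold higher number from compound 1 to compound 4 (0.74 log units; beyond the scatter) both leaving compound 4 on the side of larger doses.

From the compounds shown here alone, whether tert-butylamino in place of isopropylamino, or a longer chain between the amine and the carbonyl, would narrow that gap stays open. The true size of the methyl step also stays open because compound 3 sits at a limit: the limit of > 160 mg/kg in this assay, at which 1 of the 4 values shown sits.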